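Replacing the chain end of compound 2

The compounds below may be only part of what the source reports. "The series", "measured", "known", "first", "only" and "open" are said of these compounds alone.

Compound 2 `CS(=O)(=O)N1CCN(CCCOc2ccc([C@H]3CC[C@]4(CC3)OOC3(O4)C4CC5CC(C4)CC3C5)cc2)CC1` gives < 1.6 ug/mL in a physicochemical assay for solubility, read by nephelometry, measured as kinetic solubility, with a stated time of 30 min (a higher number here means a more soluble compound, a lower number a less soluble compound), and that value is a limit of the assay, not a number. Compound 4 `O[C@H]1CC[C@H](NCCCOc2ccc([C@H]3CC[C@]4(CC3)OOC3(O4)C4CC5CC(C4)CC3C5)cc2)CC1` differs from it in one place, on a saturated chain carbon: (4-hydroxycyclohexyl)amino in place of 4-(methylsulfonyl)piperazin-1-yl on a saturated chain carbon, three bonds along the chain from an oxygen on an aromatic ring. Compound 3 `NCCCCOc1ccc([C@H]2CC[C@]3(CC2)OOC2(O3)C3CC4CC(C3)CC2C4)cc1` gives 50 ug/mL, and compound 1 `NC1CCN(S(=O)(=O)c2ccc([C@H]3CC[C@]4(CC3)OOC3(O4)C4CC5CC(C4)CC3C5)cc2)CC1` gives 12.5 ug/mL. The closest guide is an at least 31-fold higher number from compound 2 to compound 3 (1.49 log units; beyond the scatter), a large rise where aminomethyl replaces the same group at the same place. The other measured step, a 4.0-fold higher number from compound 1 to compound 3 (0.60 log units; beyond the scatter), is modest and changes a different group, so it bears less directly. A rise is therefore expected here too, with an estimated size of an at least 15-fold higher number from compound 2 to compound 4 (1.19 log units; beyond the scatter). For compound 4 the expected value is 25 ug/mL, within an estimated range of 6 ug/mL to 100 ug/mL.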

Compound 4, solubility: > 100 ug/mL
Compound 4 was reported as a limit; the forecaster's own chance of this, stated with the estimate: 10%; at least 4.0-fold (0.60 log units) between middle value and limit.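

At this chain end, (4-hydroxycyclohexyl)amino gives an at least 62-fold higher number from compound 2 to compound 4 (1.79 log units; beyond the scatter) in this assay, so a six-membered non-aromatic ring here does not by itself keep the reading low. The other two comparisons are an at least 2.0-fold higher number from compound 3 to compound 4 (0.30 log units; that floor lies within the scatter) and an at least 8.0-fold higher number from compound 1 to compound 4 (0.90 log units; beyond the scatter). The reading of compound 4 is a limit, not a number: the limit of > 100 ug/mL in this assay, at which 1 of the 4 values shown sits.

The compounds shown do not separate the hydroxy group from the rest of (4-hydroxycyclohexyl)amino. A plain cyclohexylamino group at the same place would make that comparison.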